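The source may hold more compounds than are shown below. What is called first, only, known or untested is meant among the compounds shown, and "the series" means these compounds.

Measured in an ADME assay on J774.1 cells (Mus musculus) for cytotoxicity, read by resazurin assay, with a stated time of 48 h; a lower number here means a stronger inhibitor, a higher number a weaker inhibitor:
- compound 1 `CCCCn1cc(C(=O)NCc2ccccc2)c(=O)c2cc(F)c(N(C)C)cc21` gives > 100000 nM (a limit)
- compound 2 `CCCCn1cc(C(=O)O)c(=O)c2cc(F)c(N3CCC(C(N)=O)CC3)cc21` gives > 100000 nM (a limit)

Neither entry is a number. For the measured compounds named here, compound 2 stands at the limit of > 100000 nM in this assay, at which 2 of the 2 values shown sit, and has no measured step to any neighbour.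

Compound 3 `CCCCn1cc(C(=O)O)c(=O)c2cc(F)c(N(C)C)cc21` comes from compound 2 by dimethylamino in place of 4-carbamoylpiperidin-1-yl on an aromatic carbon; that is, dimethylamino in place of 4-carbamoylpiperidin-1-yl on an aromatic carbon. Compound 1 also carries dimethylamino and gives the limit > 100000 nM in the same read-out. No step beyond the scatter is expected in this assay, and the estimated change is a number no higher from compound 2 to compound 3 (the limit leaves the size open) here. Compound 3 is estimated at 100000 nM within a range of 50000 nM to 200000 nM and will probably read as a limit again.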

Compound 3, half-maximal inhibitory concentration: > 100000 nM
Compound 3: only a limit was reported; the forecaster's own chance of this, stated with the estimate: 85%; the middle value lies on the limit itself.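

No step can be read between compound 3 and compound 1 or compound 2 in this assay, which all stand at one limit: the limit of > 100000 nM in this assay, at which 3 of the 3 values shown sit. Open remains whether either exchange, at the aromatic carbon or the carbonyl carbon, alters the read-out at all.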